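Swapping bromo for methyl on a shared benzimidazole-type core

A few compounds are considered here, and "the series" means these few. Any claim that something is new, unique, unknown or untested is made for them only; others in the source may bear on it.

Three compounds share a core and were tested in an assay on cells for inhibition of matrix metalloproteinase-9 (Homo sapiens), read by fluorescence, with stated times of 15 min and 4 h; on this read-out higher numbers stand for weaker inhibition and lower numbers for stronger inhibition. Compound 1 `Cc1ccc2nc(-c3cccc(NC(=O)CCc4ccccc4)c3)[nH]c2c1` gives 26600 nM. Compound 2 `O=C(CCc1ccccc1)Nc1cccc(-c2nc3ccc(Br)cc3[nH]2)c1` gives 14500 nM. Compound 3 `O=[N+]([O-])c1ccc(-c2nc3ccc(Br)cc3[nH]2)cc1` gives 10000 nM. Compounds 1 and 2 differ in one place: methyl in place of bromo on an aromatic carbon. That change gave a 1.8-fold higher number from compound 2 to compound 1 (0.26 log units; within the scatter). The difference between the cores of compound 2 and compound 3 is not broken down here; their two values lie within the scatter of each other, while the value of compound 1 sits further from compound 3, beyond the scatter.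

Compound 4 `Cc1ccc2nc(-c3ccc([N+](=O)[O-])cc3)[nH]c2c1` has not yet been measured in this assay. It relates to compound 3 by the same change: methyl in place of bromo on an aromatic carbon, in the same place as before. The expected step is a 1.8-fold higher number from compound 3 to compound 4 (0.26 log units; within the scatter), because the same change gave a 1.8-fold higher number from compound 2 to compound 1 (0.26 log units; within the scatter) between compound 2 and compound 1, and a step of roughly that size is estimated here. Compound 4 is therefore expected to give about 18000 nM, with an estimated range from 8000 nM to 40000 nM.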

Compound 4, half-maximal inhibitory concentration: 22000 nM
Compound 4: middle estimate off by 1.2-fold (0.09 log units), on the low side; the measured number falls inside the stated range.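

In this assay putting methyl in place of bromo on the core of compound 3 gave a 2.2-fold higher number from compound 3 to compound 4 (0.34 log units; beyond the scatter) and so moved the number the same way as on the other core, by a modest amount. Set side by side, the two steps agree in direction and in size, so in this small set the change carries over from one core to the other: the same change on two cores in this assay, a 1.8-fold higher number (0.26 log units; within the scatter) from compound 2 to compound 1 and a 2.2-fold higher number (0.34 log units; beyond the scatter) from compound 3 to compound 4, 1.2-fold (0.08 log units) apart, within the scatter of two such steps

Among the compounds shown here, this rests on only two pairs of compounds, one step within the scatter and the other beyond it, so it shows no general rule for other cores and gives no reason for the step.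

The compounds shown leave open whether the same step would appear on a core carrying an amine or a carboxylic acid in place of the nitro group. They also leave open what a chloro, methoxy or longer alkyl chain would do in the place now held by bromo or methyl.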